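Amide Aryl Swap on a Shared Core: Compound 2 to Compound 4

This account rests on a few compounds, and the source may have more. Where it says the series, first, only, none or still open, it means among the compounds named here.

The three compounds measured in a functional assay on the whole organism for inhibition, with Rattus norvegicus as the target, read by cytopathic effect and paw edema, at a dose of 100 mg/kg by the oral route (on this read-out higher numbers stand for more inhibition at the one dose given (going by the name of the read-out) and lower numbers for less inhibition), are:

compound 1, `CCOC(=O)c1c(O)c2cccnc2n(-c2ccccc2)c1=O`, with 15.5%
compound 2, `Nc1ccc(NC(=O)c2c(O)c3cccnc3n(-c3ccccc3)c2=O)cc1`, with 0%
compound 3, `O=C(Nc1cccc([N+](=O)[O-])c1)c1c(O)c2cccnc2n(-c2ccccc2)c1=O`, with 7.4%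

Compound 2 holds the lowest of the three numbers. Compound 3 sits within the scatter of it, as a number 7.4 percentage points higher from compound 2 to compound 3 (within the scatter) shows, while compound 1 sits beyond it, as a number 15.5 percentage points lower from compound 1 to compound 2 (beyond the scatter) shows. The unmeasured compound 4, `O=C(Nc1ccc(Cl)nc1)c1c(O)c2cccnc2n(-c2ccccc2)c1=O`, differs from compound 2 in one place: 6-chloropyridin-3-yl in place of 4-aminophenyl on an amide-type nitrogen. The measured step that bears most on this is the exchange of one aryl group for another on the same amide-type nitrogen, a number 7.4 percentage points higher from compound 2 to compound 3 (within the scatter), which stays within the scatter. Against compound 1 with its ethoxy group, the two amide compounds show a number 15.5 percentage points lower from compound 1 to compound 2 (beyond the scatter) and a number 8.1 percentage points lower from compound 1 to compound 3 (within the scatter). Nothing here separates one aryl group on the amide-type nitrogen from another beyond the scatter. The step for compound 4 is therefore expected to stay within the scatter: a number 6 percentage points higher from compound 2 to compound 4 (within the scatter). The estimate for compound 4 is 6%, with a range from 0% to 18%.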

Compound 4, a percentage reported as inhibition, in the whole organism at one dose (the size of the read-out at that dose, not a potency): -4%
For compound 4 the middle estimate is 10 percentage points above the measured one; measured number outside the range, below it.
By their numbers in this assay, from the lowest: compounds 4, 2, 3 and 1 (each within the scatter of the next, the first and the last beyond it).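

In this assay, putting 6-chloropyridin-3-yl in place of 4-aminophenyl on the amide-type nitrogen gives a number 4 percentage points lower from compound 2 to compound 4 (within the scatter) and so does not separate these two groups. Within the data shown here, exchanging 3-nitrophenyl for the same 6-chloropyridin-3-yl gives a number 11.4 percentage points lower from compound 3 to compound 4 (beyond the scatter) and is the first aryl exchange at this position to pass the scatter, so the choice of aryl group can matter here. Replacing ethoxy on the carbonyl carbon with (6-chloropyridin-3-yl)amino gives a number 19.5 percentage points lower from compound 1 to compound 4 (beyond the scatter) and adds a second amide that stands clearly apart from compound 1, while compound 3 remains the amide that does not.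

Nothing measured here accounts for these steps. The compounds shown leave open whether a plain phenyl group or a short alkyl chain on the amide-type nitrogen would match or pass compound 1 in this read-out.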